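The source may report more compounds than this note shows. Statements on the series, on what has been measured and on what is new or still open speak of the compounds shown alone.

Working notes on the series. The shared core is that of compound 1 `CC(C)OC1=C(C(=O)c2ccccc2)C(c2ccc(Br)cc2)N(CCCn2ccnc2)C1=O`. In a functional assay on U2OS cells (Homo sapiens) for antiproliferative activity, read by MTT assay, with a stated time of 72 h (a higher number here means a weaker inhibitor, a lower number a stronger inhibitor), compound 1 gives 24800 nM, the highest of the three numbers in hand, so it is the weakest inhibitor among the measured compounds. Compound 2 `O=C(C1=C(Nc2ccc(I)cc2)C(=O)N(CCCn2ccnc2)C1c1ccc(Br)cc1)c1ccccc1` gives 12000 nM in this assay, and compound 3 `O=C(C1=C(Nc2cccc(Br)c2)C(=O)N(CCCn2ccnc2)C1c1ccc(Br)cc1)c1ccccc1` gives 11900 nM. Both replacements of the isopropoxy group by an arylamino group moved the number the same way: a 2.1-fold lower number from compound 1 to compound 2 (0.32 log units; beyond the scatter) and a 2.1-fold lower number from compound 1 to compound 3 (0.32 log units; beyond the scatter). The two arylamino compounds do not separate from each other, since a 1.0-fold lower number from compound 2 to compound 3 (0.00 log units; within the scatter).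

Compound 4 `O=C(C1=C(Nc2ccccc2Br)C(=O)N(CCCn2ccnc2)C1c1ccc(Br)cc1)c1ccccc1` has not been measured. Relative to compound 1 the change is (2-bromophenyl)amino in place of isopropoxy on a double-bonded ring carbon The steps that bear on it are those from compound 1 to compound 2 and from compound 1 to compound 3, both modest and in the same direction; the (4-iodophenyl)amino and (3-bromophenyl)amino variants give the same number within the scatter, so the choice between those two aryl groups made no difference that can be seen. Among the compounds with values here, a step of similar size and direction, toward a lower number, is therefore expected for compound 4, with the caveat that only two precedents exist. The expected step is a 2.1-fold lower number from compound 1 to compound 4 (0.32 log units; beyond the scatter). Compound 4 is estimated at 12000 nM in this assay, within a range from 6000 nM to 25000 nM.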

Compound 4, half-maximal inhibitory concentration: 16900 nM
For compound 4 the middle estimate is 1.4-fold (0.15 log units) below the measured one; the range from low to high includes it.
By their numbers in this assay, from the lowest: compounds 3, 2, 4 and 1 (each within the scatter of the next, the first and the last beyond it).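

In this assay the (2-bromophenyl)amino group does not separate from isopropoxy on the double-bonded ring carbon (a 1.5-fold lower number from compound 1 to compound 4 (0.17 log units; within the scatter)), so an arylamino group at this position does not always give a step beyond the scatter. Compound 4 also does not separate from either earlier arylamino compound (a 1.4-fold higher number from compound 3 to compound 4 (0.15 log units; within the scatter); a 1.4-fold higher number from compound 2 to compound 4 (0.15 log units; within the scatter)), so the 2-bromophenyl, 3-bromophenyl and 4-iodophenyl groups on the amine nitrogen cannot be told apart in this assay, and the line between compound 1 and the arylamino compounds is blurred rather than clean. Nothing on hand gives a reason for any of these numbers.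

The compounds shown leave open whether an unsubstituted phenylamino group, a methoxy-bearing phenylamino group or a non-aromatic amine such as morpholine at this position would give a number outside this narrow band. They also leave open whether the arylamino groups would separate if the benzoyl group, the 4-bromophenyl group or the 3-(1H-imidazol-1-yl)propyl group were replaced, for example by a carboxylic acid or a longer chain.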